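Para Substituent Swap on the Benzoyl Group: Compound 4

This account rests on a few compounds, and the source may have more. Where it says the series, first, only, none or still open, it means among the compounds named here.

Compound 1, `COc1ccc(C(=O)N2CCN(Cc3nc4ccccc4n3Cc3cccc(C)c3)CC2)cc1`: 55.5%
Compound 2, `Cc1cccc(Cn2c(CN3CCN(C(=O)c4ccc(C(F)(F)F)cc4)CC3)nc3ccccc32)c1`: 22.9%
Compound 3, `Cc1ccc(C(=O)N2CCN(Cc3nc4ccccc4n3Cc3cccc(C)c3)CC2)cc1`: 64.9%

Of the compounds shown here, three sharing one core have been measured in an assay on isolated protein for inhibition of aldehyde dehydrogenase 1A1 (Homo sapiens), read by spectrophotometry, tested at 10 uM; a higher number here means more inhibition at the concentration tested (going by the name of the read-out), a lower number less inhibition. Compound 3 gives the highest of the three numbers, but the step of a number 9.4 percentage points higher from compound 1 to compound 3 (within the scatter) lies within the scatter, so compound 3 and compound 1 cannot be ordered. The step of a number 42 percentage points higher from compound 2 to compound 3 (beyond the scatter) is large and separates compound 3 clearly from compound 2.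

Compound 4, `Cc1cccc(Cn2c(CN3CCN(C(=O)c4ccc(F)cc4)CC3)nc3ccccc32)c1`, differs from compound 3 in one place: fluoro in place of methyl on an aromatic carbon.

For the measured compounds named here, no measured step involves fluoro. The two steps at the same aromatic carbon are a number 9.4 percentage points higher from compound 1 to compound 3 (within the scatter), which is small, and a number 42 percentage points higher from compound 2 to compound 3 (beyond the scatter), which is large. The trifluoromethyl change shows that a change at this carbon can cost much inhibition, while the methoxy change shows that not every change here does. Fluoro is a single heavy atom, as is methyl, and the expected outcome for compound 4 is a modest loss, a number 14.9 percentage points lower from compound 3 to compound 4 (beyond the scatter), smaller than the trifluoromethyl step but possibly beyond the scatter. Compound 4 is therefore estimated at 50%, within a range of 25% to 72%.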

Compound 4, a percentage reported as inhibition, at one concentration (the size of the read-out at that concentration, not a potency): 27.1%
For compound 4 the middle estimate is 22.9 percentage points above the measured one, and the stated range covers the measured number.
By their numbers in this assay, from the lowest: compounds 2 and 4 (each within the scatter of the next); then compounds 1 and 3 (each within the scatter of the next).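

In this assay, the change at this aromatic carbon, para to a large group, proves large even when the group entering is no bigger by heavy-atom count than the one leaving: the step is a number 37.8 percentage points lower from compound 3 to compound 4 (beyond the scatter), with one heavy atom swapped for one heavy atom and neither group counted as a hydrogen-bond donor or acceptor. The four groups now fall into two pairs, since fluoro cannot be told apart from trifluoromethyl, the step being a number 4.2 percentage points higher from compound 2 to compound 4 (within the scatter), while fluoro separates from methoxy, the step being a number 28.4 percentage points lower from compound 1 to compound 4 (beyond the scatter), so methyl and methoxy stand together and the two fluorine-bearing groups stand together, and heavy-atom count alone does not sort them. No independent measurement is at hand that would explain this division into two pairs.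

On these data alone, what remains open is whether the division extends to other groups on this carbon, such as chloro, an amine or a carboxylic acid, or whether these four compounds simply show two levels by coincidence. Also open, as far as these compounds go, is whether fluoro in place of methyl gives a step of similar size when another part of the shared core is changed, and how these readings at one concentration would translate into potency.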